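Working notes on a small antiproliferative series

The compounds below may be only part of what the source reports. "The series", "measured", "known", "first", "only" and "open" are said of these compounds alone.

Measured so far:
- compound 1, `Cn1ccc2cc(-c3cnccc3/C=C/C(=O)O)ccc21`: > 10000 nM
- compound 2, `CNC(=O)CCc1ccncc1-c1ccc2ccccc2c1`: 10400 nM

Both compounds were run in a functional assay on A549 cells (Homo sapiens) for inhibition, read by sulforhodamine B assay, with a stated time of 72 h; on this read-out higher numbers stand for weaker inhibition of growth and lower numbers for stronger inhibition of growth. Compound 1 gives > 10000 nM, which is a limit of the assay and not a number. For the measured compounds named here, compound 2 gives 10400 nM, the only number in the set so far; the other entry is the limit of > 10000 nM in this assay, at which 1 of the 2 values shown sits. Compound 2 thus stands as a weak inhibitor of growth in this assay, and there is no second number against which to place it.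

The next compound, compound 3 `CCOC(=O)/C=C/c1ccncc1-c1ccc2ccccc2c1`, differs from compound 2 in one place: 2-(ethoxycarbonyl)ethenyl in place of 2-(methylcarbamoyl)ethyl on an aromatic carbon. Going by the values given here, no pair of measured compounds separated by a single change is available, so the size of the step cannot be read from the set. The change from compound 2 to compound 3 is expected to give no step beyond the usual scatter, that is a 1.2-fold lower number from compound 2 to compound 3 (0.06 log units; within the scatter). Compound 3 is therefore expected at 9000 nM, within 2500 nM to 30000 nM. Given where compound 2 stands, there is a real chance that compound 3 is reported only as a limit.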

Compound 3, concentration for 50% growth inhibition: 5380 nM
Compound 3: the middle estimate sits 1.7-fold (0.22 log units) above what was measured; low and high end bracket the measured number.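

Compound 3 gives the series its first readable step at this position, on an aromatic carbon opposite the ring nitrogen. In this assay, replacing 2-(methylcarbamoyl)ethyl with 2-(ethoxycarbonyl)ethenyl gives a 1.9-fold lower number from compound 2 to compound 3 (0.29 log units; within the scatter), even though the entering group has 0 hydrogen-bond donors against 1 in the leaving group, and 2 double bonds outside aromatic rings against 1. So this position tolerates an exchange of an amide-bearing saturated chain for an ester-bearing unsaturated one with no change beyond the scatter, while the only other entry in the set remains a limit: the limit of > 10000 nM in this assay, at which 1 of the 3 values shown sits.

The exchange alters the chain and its end group together, so the compounds shown cannot separate the double bond from the change of amide to ester, and they do not show whether any group at this place can move the number beyond the scatter. As far as these compounds go, an amine at the end of the chain, or a longer chain at the same aromatic carbon, remains open, as does any change elsewhere on the shared core.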